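Chain extension carried from one core to a second

The source may report more compounds than this note shows. Statements on the series, on what has been measured and on what is new or still open speak of the compounds shown alone.

Compound 1 `CN(c1cnccc1SCCCCC(=O)O)c1ccc(C#N)c2ccccc12` and compound 3 `CN(c1cnccc1SCCCCCCC(=O)O)c1ccc(C#N)c2ccccc12` share one core; compound 2 `N#Cc1ccc(Oc2cnccc2SCCCC(=O)O)c2ccccc12` and compound 4 `N#Cc1ccc(Oc2cnccc2SCCCCCC(=O)O)c2ccccc12` share another. The difference between the two cores is not broken down here. In an assay on HEK293 cells for inhibition of solute carrier family 22 member 12 (Homo sapiens), read by scintillation counting, with stated times of 30 min and 15 min (a lower number here means a stronger inhibitor, a higher number a weaker inhibitor), compound 1 gives 3580 nM and compound 3 gives 4640 nM. The change from compound 1 to compound 3 is 2-carboxyethyl in place of carboxy on a saturated chain carbon, four bonds along the chain from a sulfur, and it made a 1.3-fold higher number from compound 1 to compound 3 (0.11 log units; within the scatter). In this assay compound 2 gives 1230 nM, the lowest of the three measured numbers, beyond the scatter from both others. Compound 4 carries the same kind of change on its core, (2-carboxyethyl in place of carboxy on a saturated chain carbon, three bonds along the chain from a sulfur); the place here is three bonds along the chain from a sulfur rather than four, so the surroundings of the change are not identical. With one earlier example only, the step for compound 4 is expected to be of similar size, a 1.3-fold higher number from compound 2 to compound 4 (0.11 log units; within the scatter). That expectation rests on a 1.3-fold higher number from compound 1 to compound 3 (0.11 log units; within the scatter) being within the scatter. Compound 4 is therefore estimated at 1600 nM in this assay, with a range from 900 nM to 2900 nM.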

Compound 4, half-maximal inhibitory concentration: 4740 nM
Compound 4: middle estimate off by 3.0-fold (0.47 log units), on the low side; the whole stated range lies below it.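

In this assay the change of carboxy to 2-carboxyethyl on the second core gave a 3.9-fold higher number from compound 2 to compound 4 (0.59 log units; beyond the scatter), a step beyond the scatter, whereas the earlier step on the first core stayed within it. The change therefore did not carry over at the same size from one core to the other: the same change on two cores in this assay, a 1.3-fold higher number (0.11 log units; within the scatter) from compound 1 to compound 3 and a 3.9-fold higher number (0.59 log units; beyond the scatter) from compound 2 to compound 4, 3.0-fold (0.47 log units) apart, beyond the scatter of two such steps

This does not show why the two steps differ, since the cores differ and the place of the change also differs, three bonds along the chain from a sulfur rather than four, and one step on each core cannot separate these two differences or establish a rule for the series.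

Still open, going by these compounds, is whether the size of the step follows the core or the starting chain, which matched chain lengths on both cores would help to separate. Also open, on these data alone, is how a still longer chain, or an amide in place of the carboxylic acid, would behave on either core.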